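A few compounds are considered here, and "the series" means these few. Any claim that something is new, unique, unknown or untested is made for them only; others in the source may bear on it.

Measured in a functional assay on A549 cells (Homo sapiens) for antiproliferative activity, read by sulforhodamine B assay, with a stated time of 72 h; on this read-out higher numbers stand for weaker inhibition of growth and lower numbers for stronger inhibition of growth:
Compound 1, `CCc1cc(=O)c2ccc(Sc3cccc(Cl)[n+]3[O-])cc2o1`, gives > 29900 nM, a limit of the assay.
Compound 2, `CCc1cc(=O)c2ccc(Sc3cccc(Cl)[n+]3[O-])c(C)c2o1`, gives > 28700 nM, a limit of the assay.
Compound 3, `CCc1cc(=O)c2ccc(OCc3ccccc3)c(C)c2o1`, gives > 33900 nM, a limit of the assay.

No number is known for any of the three. The change from compound 1 to compound 2 is methyl in place of hydrogen on an aromatic carbon. The step that the two limits leave unreadable from compound 1 to compound 2 cannot be read, as the limit of > 28700 nM in this assay, at which 1 of the 3 values shown sits, and the limit of > 29900 nM in this assay, at which 1 of the 3 values shown sits, both sit at the limit. The difference between the core of compound 1 and that of compound 3 is not broken down here. Compound 4, `CCc1cc(=O)c2ccc(OCc3cccc(C)c3)c(C)c2o1`, is not yet measured; it differs from compound 3 by methyl in place of hydrogen on an aromatic carbon. This is the same kind of change as from compound 1 to compound 2, but the place differs: in compound 4 the methyl sits on a ring of carbon only, meta to a large group, whereas in compound 2 it sits on a ring that is part of a fused or bridged system of two rings, ortho to a fused ring. Given that compound 3 sits at the limit of > 33900 nM in this assay, at which 1 of the 3 values shown sits, compound 4 is expected to remain at the limit, with an expected step that the limit leaves unreadable from compound 3 to compound 4 in this assay. The estimate for compound 4 is 40000 nM.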

Compound 4, concentration for 50% growth inhibition: 24900 nM
For compound 4 the middle estimate is 1.6-fold (0.21 log units) above the measured one, within the range that was stated.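

In this assay the methyl on the six-membered aromatic ring of carbon only gives an at least 1.3-fold lower number from compound 3 to compound 4 (0.13 log units; that floor lies within the scatter), so phenyl to 3-methylphenyl yields a measured number on this core, though the floor of that step lies within the scatter. Compound 3 gives > 33900 nM, which is a limit of the assay. The step from compound 1 to compound 2 cannot be read, as both values are limits, and the methyl sits at a different place there, so these compounds do not show whether the change carries from one core to the other.

Open, going by these compounds, is what an amine or a carboxylic acid would give in place of this methyl. Also open, on these data alone, is whether any group on the core of compound 1 gives a number rather than a limit.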